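The compounds below may be only part of what the source reports. "The series", "measured", "known", "first", "only" and "open" are said of these compounds alone.

Measured compounds:
compound 1 `COc1ccc(Cc2nnc(CN(c3cccc(Cl)c3Cl)S(=O)(=O)c3ccc(C)cc3)o2)cc1` gives 39.8 nM
compound 2 `CCOc1ccc(Cc2nnc(CN(c3cccc(Cl)c3Cl)S(=O)(=O)c3ccc(C)cc3)o2)cc1` gives 31.6 nM
compound 3 `Cc1ccc(S(=O)(=O)N(Cc2nnc(Cc3ccc(C(F)(F)F)cc3)o2)c2cccc(Cl)c2C)cc1` gives 158 nM

All three were run in a functional assay on CHO cells for antagonist activity at prostaglandin E2 receptor EP1 subtype (Homo sapiens), read by FLIPR and calcium flux; on this read-out lower numbers stand for stronger inhibition and higher numbers for weaker inhibition. In this assay compound 3 gives the highest number of the three; compound 1 and compound 2 sit lower, and both gaps lie beyond the scatter. Among the measured compounds shown here, compound 1 and compound 2 differ from compound 3 in more than one place, so no single step joins them to it. For the measured compounds named here, the one step between compounds that differ in a single place runs from compound 1 to compound 2, a 1.3-fold lower number from compound 1 to compound 2 (0.10 log units; within the scatter), and concerns the alkoxy group only.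

Compound 4 `Cc1ccc(S(=O)(=O)N(Cc2nnc(Cc3cccc(Cl)c3)o2)c2cccc(Cl)c2C)cc1` is the next member to be measured in this assay. Relative to compound 3 it carries 3-chlorophenyl in place of 4-(trifluoromethyl)phenyl on a saturated chain carbon bound to an aromatic carbon. Going by the values given here, no measured step changes the group at this position, and the step from compound 1 to compound 2 touches a different part of the molecule, so it bears on the present change only in showing that one peripheral swap stayed within the scatter. The expectation therefore rests on compound 3 alone, with wide uncertainty. The step from compound 3 to compound 4 is expected to be a 1.3-fold lower number from compound 3 to compound 4 (0.12 log units; within the scatter). Compound 4 is estimated at 120 nM in this assay, with a range from 40 nM to 400 nM.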

Compound 4, inhibition constant: 2000 nM
Beside the measured number, compound 4's estimate is 17-fold (1.22 log units) below it, and the stated range ends below it.
By their numbers in this assay, from the lowest: compounds 2 and 1 (each within the scatter of the next); then compound 3; then compound 4.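

In this assay, the group on a saturated chain carbon bound to an aromatic carbon proves to be a sensitive position. Placing 3-chlorophenyl there in place of 4-(trifluoromethyl)phenyl gives a 13-fold higher number from compound 3 to compound 4 (1.10 log units; beyond the scatter), a large step beyond the scatter, whereas the only earlier single-place step, at the alkoxy group, stayed within it. The two compounds differ in this one place, so the whole weakening belongs to this swap, although no measurement on hand bears on why the number moves so far.

The pair changes the substituent and its numbered ring location together, so 4-chlorophenyl and 3-(trifluoromethyl)phenyl at the same place would be needed to tell which of the two changes goes with the weakening. Also open, from the compounds shown here alone, is whether the same swap would have a similar effect on the core of compound 1, and how an unsubstituted phenyl, or a phenyl bearing a carboxylic acid or an amine, would read at this position.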